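Methylamino on the Seven-Membered Ring of Compound 1

The compounds below may be only part of what the source reports. "The series", "measured", "known", "first", "only" and "open" are said of these compounds alone.

Compound 1 `CCOC(=O)C(=O)Nc1cccccc1=O` is the reference point of this set. In a functional assay on the whole organism (strain Sprague-Dawley CD) for inhibition, with Rattus norvegicus as the target, read by paw edema, at a dose of 30 mg/kg by the intraperitoneal route (a higher number here means a stronger effect of the compound at the dose given, a lower number a weaker effect), compound 1 gives 84%, the highest of the three numbers recorded. Compound 3 `CCOC(=O)C(=O)Nc1ccccc(N(C)S(=O)(=O)c2ccc(C)cc2)c1=O` comes nearest to it: in this assay compound 3 gives 32%, which lies beyond the usual scatter below compound 1. Compound 2 `CCOC(=O)C(=O)Nc1ccc(O)c(=O)cc1` stands furthest away; in this assay compound 2 gives 10%, also beyond the scatter below compound 1. Among the measured compounds shown here, none of these three compounds differs from another in a single place, so these pairs show only what their two values show and allow no step to be traced.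

Compound 4 `CCOC(=O)C(=O)Nc1ccccc(NC)c1=O` has not yet been measured. It differs from compound 1 in one way: methylamino in place of hydrogen on an aromatic carbon. Compound 3 also carries a substituent of its own on the shared core, and its number in this assay falls well short of compound 1, while compound 2 bears a different pattern on its ring and is weaker still. On that basis a drop beyond the scatter is expected for compound 4, though the methylamino group is far smaller than the group carried by compound 3. Compound 4 in this assay is estimated at 55%, within a range of 30% to 80%. The expected step is a number 29 percentage points lower from compound 1 to compound 4 (beyond the scatter), a loss larger than the scatter.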

Compound 4, a percentage reported as inhibition, in the whole organism at one dose (the size of the read-out at that dose, not a potency): 83%
Beside the measured number, compound 4's estimate is 28 percentage points below it; the measured number lies above the stated range.
By their numbers in this assay, from the lowest: compound 2; then compound 3; then compounds 4 and 1 (each within the scatter of the next).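

In this assay, methylamino in place of hydrogen on an aromatic carbon, two ring bonds from the ring atom that bears the group of 8 heavy atoms, gives a number 1 percentage points lower from compound 1 to compound 4 (within the scatter), so at this one dose the change leaves no effect that can be read apart from the scatter. Among the compounds shown here, this is the first step in the set that isolates a single place, and it shows that this carbon of the seven-membered ring can carry methylamino, with its 2 heavy atoms, while the read-out stays within the scatter of the unsubstituted parent. No measurement shown offers an explanation for this result.

The compounds shown leave open how far this tolerance extends at the same carbon, for instance to dimethylamino, a longer chain such as butylamino, or a carboxylic acid, and whether methylamino would give the same outcome on another carbon of the ring. Since the read-out is taken at a single dose and is not a potency, they also leave open whether the two compounds would stay within the scatter of each other at lower doses.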